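The compounds below may be only part of what the source reports. "The series", "measured", "known", "first", "only" and "open" are said of these compounds alone.

Measured so far:
compound 1 `O=C(O)CCC[C@H](O)[C@@H](/C=C\CCCCCc1ccccc1)Sc1ccc(C(=O)O)cc1` — 20000 nM
compound 2 `O=C(O)CCC[C@H](O)[C@@H](/C=C\CCCCCCCCc1ccccc1)Sc1ccc(C(=O)O)cc1` — 316 nM
compound 3 `O=C(O)CCC[C@H](O)[C@@H](/C=C\CCCCCCCCOc1ccccc1)Sc1ccc(C(=O)O)cc1` — 631 nM

In an assay on membranes from lung for binding affinity to cysteinyl leukotriene receptor 1 (Cavia porcellus) (a lower number here means a stronger inhibitor, a higher number a weaker inhibitor), compound 3 stands second highest of the three numbers; the gap to compound 2 is within the scatter, the gap to compound 1 is beyond it. Compound 4 `O=C(O)CCC[C@H](O)[C@@H](/C=C\CCCCCCCCCCCc1ccccc1)Sc1ccc(C(=O)O)cc1` has not yet been measured. Its change from compound 3 is 3-phenylpropyl in place of phenoxy on a saturated chain carbon, eight bonds along the chain from a double-bonded chain carbon. For the measured compounds named here, two steps bear on it: a 2.0-fold higher number from compound 2 to compound 3 (0.30 log units; within the scatter), so swapping phenoxy for phenyl at this place hardly matters, and a 63-fold lower number from compound 1 to compound 2 (1.80 log units; beyond the scatter), where lengthening the chain toward the phenyl by three carbons gave a large drop. Going by the values given here, compound 4 extends the chain once more, which no measured pair covers. A modest further lowering is therefore expected, a 3.2-fold lower number from compound 3 to compound 4 (0.50 log units; beyond the scatter), with wide uncertainty. For compound 4 the estimate is 200 nM, range 40 nM to 1000 nM.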

Compound 4, inhibition constant: 1260 nM
The estimate for compound 4 lay 6.3-fold (0.80 log units) below the measured number, and the stated range ends below it.
By their numbers in this assay, from the lowest: compounds 2, 3 and 4 (each within the scatter of the next, the first and the last beyond it); then compound 1.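

In this assay, the longer tail brings no gain at this place: a 2.0-fold higher number from compound 3 to compound 4 (0.30 log units; within the scatter), and measured against the phenyl-ended chain there is a 4.0-fold higher number from compound 2 to compound 4 (0.60 log units; beyond the scatter), so the fall in the number with chain length does not continue beyond compound 2. Much of the gain over the shortest chain remains, with a 16-fold lower number from compound 1 to compound 4 (1.20 log units; beyond the scatter). Nothing available explains this turn.

Open, from the compounds shown here alone, is whether a chain length between those of compound 2 and compound 4 gives a lower number. Also open, going by these compounds, is how an amine or a carboxylic acid at the chain end would compare with the phenyl.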